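Compound 3 to compound 4: a larger group on the ring nitrogen

The source may report more compounds than this note shows. Statements on the series, on what has been measured and on what is new or still open speak of the compounds shown alone.

Of the compounds shown here, three have been measured in a functional assay on DU-145 cells (Homo sapiens) for cytotoxicity, read by trypan blue exclusion, with a stated time of 96 h; on this read-out lower numbers stand for stronger inhibition and higher numbers for weaker inhibition. Compound 1 `COc1cc(OC)c(/C=C/S(=O)(=O)Nc2cc([N+](=O)[O-])c(OC)c([N+](=O)[O-])c2)c(OC)c1` gives 10000 nM, and compound 2 `O=S(=O)(/C=C/c1ccc(Br)cc1)Nc1ccc(F)cc1` gives 10000 nM, the same high level in both cases. Compound 3 `COC(=O)CNc1cc(NS(=O)(=O)/C=C/c2c(OC)cc(OC)cc2OC)ccc1OC` gives 350 nM, the lowest number of the three; its distance from compound 1 and from compound 2 is well beyond the scatter, so compound 3 is the most potent of the measured set.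

Compound 4 `COc1cc(OC)c(/C=C/S(=O)(=O)Nc2ccc(OC)c(NC(C(=O)O)c3ccc(Cl)cc3)c2)c(OC)c1` has not yet been measured. It differs from compound 3 in a single place: carboxy(4-chlorophenyl)methyl in place of (methoxycarbonyl)methyl on a nitrogen on an aromatic ring. Among the measured compounds shown here, no measured pair shows this change, so its effect cannot be read from the numbers at hand, and the expectation rests on compound 3 alone. Since a change of this extent is as likely to weaken as to keep the activity, and because compound 3 stands at 350 nM, compound 4 is expected to give 1000 nM, within a range from 200 nM to 8000 nM. That estimate means an expected step of a 2.9-fold higher number from compound 3 to compound 4 (0.46 log units; beyond the scatter), a modest loss that may or may not exceed the scatter.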

Compound 4, half-maximal inhibitory concentration: 75 nM
For compound 4 the middle estimate is 13-fold (1.12 log units) above the measured one, and the stated range ends above it.
By their numbers in this assay, from the lowest: compound 4; then compound 3; then compounds 1 and 2 (each within the scatter of the next).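

In this assay, this nitrogen on an aromatic ring accepts a much larger group without any loss of activity: carboxy(4-chlorophenyl)methyl in place of (methoxycarbonyl)methyl gives a 4.7-fold lower number from compound 3 to compound 4 (0.67 log units; beyond the scatter), a modest gain that lies beyond the scatter. The earlier compounds shown here could not show this, since no measured pair among them differed in one place. Nothing measured here explains why the number falls.

This single step changes two things at once, adding a chlorine-bearing aromatic ring and replacing the methyl ester with a carboxy group, so the share of each in the gain cannot be separated. Going by these compounds, how a plain phenyl without the chlorine, or an amide in place of the carboxy group, would behave at this position remains open.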